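From 4-fluorophenyl to 3-methylphenyl on a shared core

This account rests on a few compounds, and the source may have more. Where it says the series, first, only, none or still open, it means among the compounds named here.

In an ADME assay on Huh7.5.1 cells (Homo sapiens) for cytotoxicity, read by ATP content, with a stated time of 48 h (on this read-out lower numbers stand for higher toxicity in this test and higher numbers for lower toxicity in this test), compound 1 `Cc1oc(-c2ccc(F)cc2)nc1CN1CCC(C(=O)NCCCN2C[C@H](C)C[C@H](C)C2)CC1` gives 12800 nM. Compound 2 `Cc1ccccc1-c1nc(CN2CCC(C(=O)NCCCN3[C@H](C)CCC[C@@H]3C)CC2)c(C)o1` gives 21300 nM, which lies within the usual scatter of the number for compound 1. Compound 3 `Cc1ccccc1-c1nc(CN2CCC(C(=O)N3CCN(CCN(C)C)CC3)CC2)c(C)o1` gives 27200 nM, a higher number than that of compound 1 and beyond the scatter. Compound 1 therefore stands clearly apart only from compound 3.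

Compound 4 `Cc1cccc(-c2nc(CN3CCC(C(=O)NCCCN4C[C@H](C)C[C@H](C)C4)CC3)c(C)o2)c1` differs from compound 1 in one place, with 3-methylphenyl in place of 4-fluorophenyl on an aromatic carbon. The rest of compound 1 stays as it is. Among the compounds with values here, no measured pair isolates this change, so the data do not show its size directly. Within the data shown here, the only guide is that compound 2, at 21300 nM, and compound 3, at 27200 nM, also carry a methyl-bearing phenyl group and show no drop in the number compared with compound 1. In this assay, no step beyond the scatter is therefore expected. The estimated step is a 1.2-fold higher number from compound 1 to compound 4 (0.07 log units; within the scatter), which would leave the two compounds hard to tell apart. For compound 4 the expected value is 15000 nM, with an estimated range from 8000 nM to 28000 nM.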

Compound 4, half-maximal cytotoxic concentration: 16500 nM
Estimate against measurement, compound 4: 1.1-fold (0.04 log units) below; low and high end bracket the measured number.
By their numbers in this assay, from the lowest: compounds 1, 4, 2 and 3 (each within the scatter of the next, the first and the last beyond it).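

Within the data shown here, the step of a 1.3-fold higher number from compound 1 to compound 4 (0.11 log units; within the scatter) is the first direct reading of a change at this position in this assay, on an aromatic carbon of a five-membered aromatic ring with 1 nitrogen and 1 oxygen. Both groups have 7 heavy atoms and one six-membered aromatic ring of carbon only, and replacing 4-fluorophenyl with 3-methylphenyl leaves compound 1 and compound 4 hard to tell apart in this read-out, so this exchange, which removes the fluorine and adds a methyl group at a different ring position, has no effect that this test can resolve on this scaffold. Nothing available here explains why the number stays within the scatter.

This single pair cannot separate the loss of the fluorine from the gain of the methyl group, and it cannot show whether their contributions are each small or happen to offset each other. It also leaves open whether a much different group at this position, such as a carboxylic acid or an amine on the phenyl ring, would give a step beyond the scatter.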